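Chloropyridinyl amides: where the chlorine sits

The source may report more compounds than this note shows. Statements on the series, on what has been measured and on what is new or still open speak of the compounds shown alone.

Measured so far in an ADME assay on HEK293 cells (Homo sapiens) for inhibition, with a stated time of 72 h; a higher number here means that more compound is needed for the effect, a lower number that less compound is needed:

compound 1 `C/C=C/C(=O)Nc1cccc(-c2nc3ccccc3s2)c1`: > 25000 nM, a limit of the assay
compound 2 `O=C(Nc1cccc(-c2nc3ccccc3s2)c1)c1ccc(Cl)nc1Cl`: > 25000 nM, a limit of the assay
compound 3 `O=C(Nc1cccc(-c2nc3ccccc3s2)c1)c1ccnc(Cl)c1`: > 25000 nM, a limit of the assay

Compound 3 stands at the limit of > 25000 nM in this assay, at which 3 of the 3 values shown sit, as do the other two. Every step between them, a step that the two limits leave unreadable from compound 1 to compound 2, a step that the two limits leave unreadable from compound 1 to compound 3 and a step that the two limits leave unreadable from compound 2 to compound 3, is therefore unreadable in size and direction. Compound 4 `O=C(Nc1cccc(-c2nc3ccccc3s2)c1)c1ccncc1Cl` differs from compound 3 only in the place of the chlorine: 3-chloropyridin-4-yl in place of 2-chloropyridin-4-yl on a carbonyl carbon. Among the compounds with values here, no measured step bears readably on this change. With compound 3 at the limit, compound 4 is expected to remain there as well, with no step beyond the scatter expected, a step that the limit leaves unreadable from compound 3 to compound 4. The estimate for compound 4 in this assay is 40000 nM, within 15000 nM to 150000 nM.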

Compound 4, half-maximal effective concentration: > 25000 nM
Compound 4 was reported as a limit (the forecaster's own chance of this, stated with the estimate: 85%); the middle value does not contradict the limit.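

No step from compound 1, compound 2 or compound 3 to compound 4 can be read in this assay, as all four compounds sit at the same limit: the limit of > 25000 nM in this assay, at which 4 of the 4 values shown sit.

On these data alone, whether the place of the chlorine affects the result in this assay remains open.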